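Compound 3: methyl in place of methoxy

A few compounds are considered here, and "the series" means these few. Any claim that something is new, unique, unknown or untested is made for them only; others in the source may bear on it.

In a functional assay on KG-1a cells (Homo sapiens) for cytotoxicity, with a stated time of 24 h (on this read-out lower numbers stand for stronger inhibition and higher numbers for weaker inhibition), compound 1 (`Nn1c(SCc2ccc(Br)cc2)nnc1-c1c[nH]c2ccccc12`) gives 55800 nM as a measured number. Compound 2 (`COc1ccc(CSc2nnc(-c3c[nH]c4ccccc34)n2N)cc1`) sits at > 100000 nM which is a limit of the assay and not a number. Methoxy in place of bromo on an aromatic carbon gave an at least 1.7-fold higher number from compound 1 to compound 2 (0.25 log units; that floor lies within the scatter) and is the only measured step bearing on what follows. Compound 3 (`Cc1ccc(CSc2nnc(-c3c[nH]c4ccccc34)n2N)cc1`) has methyl in place of methoxy on an aromatic carbon, para to a large group (methyl in place of methoxy on an aromatic carbon). On that single step, no change beyond the scatter is expected in this assay for this swap. The estimated step is an at least 1.2-fold lower number from compound 2 to compound 3 (0.09 log units; that floor lies within the scatter) and another limit result remains possible. Compound 3 is estimated at 80000 nM within 40000 nM to 160000 nM in this read-out.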

Compound 3, half-maximal inhibitory concentration: > 100000 nM
Compound 3: no number, only a limit (the forecaster's own chance of this, stated with the estimate: 40%); at least 1.2-fold (0.09 log units) between middle value and limit.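

Compound 3 gives > 100000 nM, a limit of the assay and not a number. With methyl as with methoxy on this aromatic carbon, no measured number appears, and the step from methoxy to methyl cannot be read because both results are limits: the limit of > 100000 nM in this assay, at which 2 of the 3 values shown sit. Methyl in place of bromo gives an at least 1.7-fold higher number from compound 1 to compound 3 (0.25 log units; that floor lies within the scatter), so compound 1 cannot be set apart from compound 3 beyond the scatter. Open, as far as these compounds go, is whether a nitrile or an amine on this aromatic carbon would give a measured number, and how compound 2 and compound 3 compare beyond the limit.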